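Chloro for nitro on the pyrazole aryl ring

The source may report more compounds than this note shows. Statements on the series, on what has been measured and on what is new or still open speak of the compounds shown alone.

The three measured compounds share one core and differ only in the aryl group attached to the five-membered ring. Compound 1 `COc1ccc(-c2nn(-c3ccccc3)cc2/C=C/C(=O)c2ccc(OCc3ccccc3)c3c2OC(C)(C)C3)cc1` carries a 4-methoxyphenyl group, and in a functional assay on PC-3 cells (Homo sapiens) for antiproliferative activity, read by MTT assay, with a stated time of 48 h (a higher number here means a weaker inhibitor, a lower number a stronger inhibitor), compound 1 gives 7900 nM. Compound 2 `CC1(C)Cc2c(ccc(C(=O)/C=C/c3cn(-c4ccccc4)nc3-c3ccccc3)c2OCc2ccccc2)O1` carries an unsubstituted phenyl group; in this assay compound 2 gives only a limit, > 100000 nM. Compound 3 `CC1(C)Cc2c(ccc(C(=O)/C=C/c3cn(-c4ccccc4)nc3-c3cccc([N+](=O)[O-])c3)c2OCc2ccccc2)O1` carries a 3-nitrophenyl group; in this assay compound 3 likewise gives only a limit, > 100000 nM. Going by the values given here, compound 3 therefore stands at the edge of what this assay can report, and the one measured step that touches it, a step that the two limits leave unreadable from compound 2 to compound 3, cannot be sized, because both ends sit at the limit of > 100000 nM in this assay, at which 2 of the 3 values shown sit.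

Compound 4 `CC1(C)Cc2c(ccc(C(=O)/C=C/c3cn(-c4ccccc4)nc3-c3ccc(Cl)cc3)c2OCc2ccccc2)O1` arises from compound 3 by a single change, (4-chlorophenyl in place of 3-nitrophenyl on an aromatic carbon), that is, 4-chlorophenyl in place of 3-nitrophenyl on an aromatic carbon. Among the compounds with values here, no measured step bears directly on this exchange, and the only reading that is a number, that of compound 1, belongs to a different aryl group. Compound 4 is thus expected to sit between the number of compound 1 and the limit shared by compound 2 and compound 3, and the step of an at least 2.5-fold lower number from compound 3 to compound 4 (0.39 log units; beyond the scatter) is an estimate, not a measurement. Compound 4 is expected to give about 40000 nM in this assay, within 7000 nM to 200000 nM.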

Compound 4, half-maximal inhibitory concentration: 26000 nM
Estimate against measurement, compound 4: 1.5-fold (0.19 log units) above; the measured number falls inside the stated range.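

Compound 4 shows that an aryl group other than the 4-methoxyphenyl of compound 1 can bring the reading at this aromatic carbon of the five-membered ring off the limit in this assay: the exchange of 3-nitrophenyl for 4-chlorophenyl gives an at least 3.8-fold lower number from compound 3 to compound 4 (0.58 log units; beyond the scatter). Chloro in place of hydrogen on the phenyl group gives an at least 3.8-fold lower number from compound 2 to compound 4 (0.58 log units; beyond the scatter), so this position now has readable steps, whereas the step between compound 2 and compound 3 cannot be read. Both sizes are lower bounds only, because each step starts from a limit rather than a number: the limit of > 100000 nM in this assay, at which 2 of the 4 values shown sit.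

The exchange from 3-nitrophenyl to 4-chlorophenyl alters both the substituent and where it sits on the phenyl ring, so the compounds shown do not separate these two changes, and the true values of compound 2 and compound 3 remain unknown. On these data alone, what an amine, a carboxylic acid or a longer chain would give in place of the chloro on this phenyl group also stays open.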